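The source may hold more compounds than are shown below. What is called first, only, known or untested is meant among the compounds shown, and "the series" means these compounds.

Measured compounds:
Compound 1 `O=C(Nc1cccc(CNc2nccnc2Cl)c1)Nc1cccc2ccccc12` reaches in a functional assay on T-24 cells (Homo sapiens) for antiproliferative activity, read by MTT assay, with a stated time of 48 h (on this read-out higher numbers stand for weaker inhibition and lower numbers for stronger inhibition), only a limit of the assay, > 40000 nM.
Compound 2 `O=C(Nc1ccccc1)Nc1cccc(CNc2nccnc2Cl)c1` gives in this assay 19800 nM.

Among the measured compounds shown here, compound 2 thus stands as the only measured number in this set. For the measured compounds named here, the other value belongs to compound 1 and is a limit (the limit of > 40000 nM in this assay, at which 1 of the 2 values shown sits), so no step between measured compounds can be computed. The unmeasured compound 3 `O=C(Nc1cccc(CNc2nccnc2Cl)c1)NC1CCCC1` differs from compound 2 in one place: cyclopentyl in place of phenyl on an amide-type nitrogen. Without any measured step to lean on, the account expects the step in this assay to be small, most likely none beyond the scatter, with a slight lean towards weaker inhibition, estimated as a 1.4-fold higher number from compound 2 to compound 3 (0.15 log units; within the scatter). Compound 3 is accordingly expected to show 28000 nM in this assay, within a range from 10000 nM to 70000 nM, and there is a real chance that only a limit is reported for it.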

Compound 3, half-maximal inhibitory concentration: > 40000 nM
Compound 3 gave a limit, no number; the forecaster's own chance of this, stated with the estimate: 40%; middle value at least 1.4-fold (0.15 log units) away from the limit.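

Placing cyclopentyl instead of phenyl on the amide-type nitrogen gives, in this assay, an at least 2.0-fold higher number from compound 2 to compound 3 (0.30 log units; that floor lies within the scatter). Among the compounds shown here, this is the first step that can be read at this position, but it is only a floor: the true size of the change cannot be read, and the floor alone does not separate the change from the scatter. Compound 2 remains the only compound with a number, while compound 1 and compound 3 both stop at a limit of the assay, so no step between those two can be read: the limit of > 40000 nM in this assay, at which 2 of the 3 values shown sit.

The compounds shown leave open whether an open chain such as n-butyl, or a phenyl carrying a methoxy group or a chlorine atom, would give a number on that nitrogen. They also leave open whether any group there would bring the number lower than compound 2 does.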